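The source may hold more compounds than are shown below. What is called first, only, known or untested is meant among the compounds shown, and "the series" means these compounds.

Measured compounds:
compound 1 `COc1ncnc2c1c(-c1ccsc1)cn2[C@@H]1O[C@H](CO)[C@@H](O)[C@H]1O` — 5170 nM
compound 2 `COc1nc(N)nc2c1c(-c1ccsc1)cn2[C@@H]1O[C@H](CO)[C@@H](O)[C@H]1O` — > 100000 nM
compound 3 `O=c1[nH]cnc2c1c(-c1ccco1)cn2[C@@H]1O[C@H](CO)[C@@H](O)[C@H]1O` — > 20000 nM

In a functional assay on A549 cells (Homo sapiens), read by MTT assay, with a stated time of 72 h (a higher number here means a weaker inhibitor, a lower number a stronger inhibitor), compound 1 gives 5170 nM. For compound 2 the value is a limit of the assay, > 100000 nM. For compound 3 the value is also a limit, > 20000 nM. The change amino in place of hydrogen on an aromatic carbon gave an at least 19-fold higher number from compound 1 to compound 2 (1.28 log units; beyond the scatter). The difference between the cores of compound 1 and compound 3 is not broken down here. Compound 4 `Nc1nc2c(c(-c3ccco3)cn2[C@@H]2O[C@H](CO)[C@@H](O)[C@H]2O)c(=O)[nH]1` carries the same kind of change, (amino in place of hydrogen on an aromatic carbon); around the place, what differs is that in compound 1 the carbon is meta to a methoxy group, in compound 3 meta to a group of 1 heavy atom. Compound 4 is expected to sit at or beyond the limit of compound 3, because an at least 19-fold higher number from compound 1 to compound 2 (1.28 log units; beyond the scatter) went strongly toward weaker inhibition; the expected step is a step that the limit leaves unreadable from compound 3 to compound 4. Compound 4 is estimated at 100000 nM, between 30000 nM and 400000 nM.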

Compound 4, half-maximal inhibitory concentration: > 20000 nM
Compound 4: a limit, no number; the forecaster's own chance of this, stated with the estimate: 85%; the middle value lies beyond the limit too.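

In this assay compound 4 gives only a limit, > 20000 nM. Compound 3 also gives only a limit, > 20000 nM, so the step between these two compounds cannot be read. The compounds shown leave open how much amino in place of hydrogen changes the inhibition on the core of compound 3.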